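Changing the amide group of compound 2

The source may report more compounds than this note shows. Statements on the series, on what has been measured and on what is new or still open speak of the compounds shown alone.

Values in a physicochemical assay for permeability, using PAMPA; on this read-out higher numbers stand for higher permeability and lower numbers for lower permeability
- Compound 1 `Cc1ccccc1-c1nc(CN2CCC(C(=O)NCCCN3CC(C)(C)CC(C)(C)C3)CC2)c(C)o1` gives > 1390 10^-6 cm/s, which is a limit and not a number
- Compound 2 `Cc1ccccc1-c1nc(CN2CCC(C(=O)NCCCN3CCCCC3)CC2)c(C)o1` gives 34.5 10^-6 cm/s
- Compound 3 `Cc1ccccc1-c1nc(CN2CCC(C(=O)NCCCN3[C@H](C)CCC[C@@H]3C)CC2)c(C)o1` gives 55.4 10^-6 cm/s

Compound 2 has one close neighbour on these numbers, the step being a 1.6-fold higher number from compound 2 to compound 3 (0.21 log units; within the scatter). Two other steps are large: an at least 40-fold lower number from compound 1 to compound 2 (1.60 log units; beyond the scatter) and an at least 25-fold lower number from compound 1 to compound 3 (1.39 log units; beyond the scatter). Both start from compound 1, whose value is a limit: the limit of > 1390 10^-6 cm/s in this assay, at which 1 of the 3 values shown sits.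

Compound 4 `Cc1ccccc1-c1nc(CN2CCC(C(=O)N3CCN(CCN(C)C)CC3)CC2)c(C)o1` changes a different place: 4-(2-(dimethylamino)ethyl)piperazin-1-yl in place of (3-(piperidin-1-yl)propyl)amino on a carbonyl carbon. The new group sits on the carbonyl carbon and carries 0 hydrogen-bond donors. Among the measured compounds shown here, none of the measured steps changes this place, since all three swap a ring group on a saturated chain carbon, so they offer only a rough guide to size. The two large steps, an at least 40-fold lower number from compound 1 to compound 2 (1.60 log units; beyond the scatter) and an at least 25-fold lower number from compound 1 to compound 3 (1.39 log units; beyond the scatter), both came with fewer carbon atoms in the group. Here the leaving and entering groups hold the same number of carbon atoms, so no step of that size is expected. The expected change is small and leans towards a lower number, and the estimated step is a 1.7-fold lower number from compound 2 to compound 4 (0.24 log units; within the scatter). Compound 4 is expected at 20 10^-6 cm/s, with an estimated range of 5 10^-6 cm/s to 80 10^-6 cm/s.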

Compound 4, apparent permeability: 14 10^-6 cm/s
For compound 4 the middle estimate is 1.4-fold (0.15 log units) above the measured one, within the range that was stated.
By their numbers in this assay, from the lowest: compound 4; then compounds 2 and 3 (each within the scatter of the next). At a limit, above all of these: compound 1.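

Among the compounds shown here, changing the group on the carbonyl carbon itself, rather than the ring group at the far end of the chain, gives in this assay a step that can be read: a 2.5-fold lower number from compound 2 to compound 4 (0.39 log units; beyond the scatter) is the first change from compound 2 to lie beyond the scatter, whereas a 1.6-fold higher number from compound 2 to compound 3 (0.21 log units; within the scatter) stays within it. Compound 4 also differs in kind from compounds 1, 2 and 3, since the amide hydrogen is gone: the entering 4-(2-(dimethylamino)ethyl)piperazin-1-yl has 0 hydrogen-bond donors where the leaving group has 1. The donor count, the ring and the chain all change in this one swap, so the step belongs to the swap as a whole, and nothing measured here speaks to what lies behind it.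

The compounds shown leave open which part of the swap carries the step, and an amide that keeps the (3-(piperidin-1-yl)propyl) chain but has a methyl group in place of the amide hydrogen would begin to separate these parts. Also open, going by these compounds, is how the number would respond to a morpholine ring or a longer chain in the entering group.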